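This account rests on a few compounds, and the source may have more. Where it says the series, first, only, none or still open, it means among the compounds named here.

Of the compounds shown here, three of one series have so far been tested in a functional assay on KB cells (Homo sapiens) for inhibition; on this read-out lower numbers stand for stronger inhibition and higher numbers for weaker inhibition. Compound 1, `NC(=S)c1c(N)n(COCc2ccccc2)c2ncnc(N)c12`, gives 225000 nM. Compound 2, `COc1ccc(Cn2c(N)c(C#N)c3c(N)ncnc32)cc1`, gives 50000 nM, which is the lowest of the two numbers recorded; the gap between compound 2 and compound 1 lies beyond the usual scatter of this assay, so compound 2 is the more potent of the pair. Compound 3, `COCCOCN1c2ncnc(N)c2C(C(=N)S)C1N`, sits at the limit of > 320000 nM in this assay, at which 1 of the 3 values shown sits, a limit of the assay rather than a measured number, entered as > 320000 nM.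

The next compound to be measured is compound 4, `Cc1ccc(Cn2c(N)c(C#N)c3c(N)ncnc32)cc1`. It differs from compound 2 in a single place: methyl in place of methoxy on an aromatic carbon. The methoxy group leaves and a methyl enters at the same aromatic carbon, so the shared core and everything else remain untouched.

Among the measured compounds shown here, no pair of measured compounds differs in just one place, so there is no directly comparable step to lean on. Given how small the change is, the step from compound 2 to compound 4 in this assay is expected to be no change at the digits printed from compound 2 to compound 4 (within the scatter), that is, none beyond the scatter in either direction. Because compound 2 gives 50000 nM, compound 4 is estimated at 50000 nM, with a likely range from 20000 nM to 130000 nM.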

Compound 4, half-maximal inhibitory concentration: > 100000 nM
Compound 4: a limit, no number; the forecaster's own chance of this, stated with the estimate: 10%; at least 2.0-fold (0.30 log units) between middle value and limit.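

Among the compounds shown here, this is the first comparison between two compounds that differ in one place, here an aromatic carbon para to a large group. In this assay compound 4 has no measured number, only a limit: the limit of > 100000 nM in this assay, at which 1 of the 4 values shown sits. Methyl in place of methoxy gives an at least 2.0-fold higher number from compound 2 to compound 4 (0.30 log units; that floor lies within the scatter), so the swap brings no gain in inhibition at this carbon, but the result does not establish a real loss, and the true size of the step remains unknown.

The compounds shown leave open what a different group on this carbon would do, such as a plain hydrogen, a chlorine, an ethoxy chain or a dimethylamino group, and so whether methoxy is better than other groups there or merely one acceptable choice. Also open, going by these compounds, is how far the true value of compound 4 lies beyond its limit, which would decide whether replacing methoxy with methyl matters at all on this read-out.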